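Trifluoromethyl for Chloro on the Chain-Terminal Ring

The source may hold more compounds than are shown below. What is called first, only, known or untested is meant among the compounds shown, and "the series" means these compounds.

Compound 2 `C#CCNC1CCc2c(SCCc3ccc(Cl)cc3)cccc21` stands lowest of the three compounds measured in an assay on isolated protein for inhibition of Amine oxidase [flavin-containing] B (Homo sapiens) (on this read-out higher numbers stand for weaker inhibition and lower numbers for stronger inhibition), giving 10800 nM. Compound 1 `C#CCNC1CCc2c(SCCc3ccc(Br)cc3)cccc21` gives 85300 nM and compound 3 `C#CCNC1CCc2c(SCCc3cccc(Br)c3)cccc21` gives 30500 nM; the steps were a 7.9-fold lower number from compound 1 to compound 2 (0.90 log units; beyond the scatter), a 2.8-fold lower number from compound 1 to compound 3 (0.45 log units; beyond the scatter) and a 2.8-fold higher number from compound 2 to compound 3 (0.45 log units; beyond the scatter). Compound 4 `C#CCNC1CCc2c(SCCc3ccc(C(F)(F)F)cc3)cccc21` differs from compound 2 by trifluoromethyl in place of chloro on an aromatic carbon. Going by the values given here, only the step from compound 1 to compound 2 bears on a change of the group on this ring, and it was modest; no trifluoromethyl analogue has been measured. A modest rise is therefore expected, a 2.3-fold higher number from compound 2 to compound 4 (0.36 log units; beyond the scatter), with wide uncertainty in either direction. Compound 4 is estimated at 25000 nM, within 6000 nM to 100000 nM.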

Compound 4, half-maximal inhibitory concentration: 16100 nM
Beside the measured number, compound 4's estimate is 1.6-fold (0.19 log units) above it; the range from low to high includes it.
By their numbers in this assay, from the lowest: compounds 2, 4 and 3 (each within the scatter of the next, the first and the last beyond it); then compound 1.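

In this assay, trifluoromethyl, with its 4 heavy atoms against the 1 of chloro, leaves the read-out within the scatter, at a 1.5-fold higher number from compound 2 to compound 4 (0.17 log units; within the scatter). Trifluoromethyl also stands clear of bromo at this aromatic carbon, with a 5.3-fold lower number from compound 1 to compound 4 (0.72 log units; beyond the scatter), so the step away from bromo now holds for two replacing groups, chloro and trifluoromethyl. Nothing available explains these results.

On these data alone, whether a nitrile, a methoxy group or an amine at this aromatic carbon would stay level with chloro and trifluoromethyl remains open. So does whether a longer chain to this ring would keep that level.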